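From Cyclopropyl to Cyclohexyl on the Sulfonyl Sulfur

This account rests on a few compounds, and the source may have more. Where it says the series, first, only, none or still open, it means among the compounds named here.

Compound 1, `Cc1nc(C(=O)N2CCc3nc(C#Cc4ccccc4)sc3C2)cs1`: in an assay on HEK293 cells for negative allosteric modulation of metabotropic glutamate receptor 5 (Homo sapiens), read by FLIPR, with a stated time of 1 h (on this read-out lower numbers stand for stronger inhibition and higher numbers for weaker inhibition), compound 1 gives > 10000 nM, a limit of the assay and not a number.
Compound 2, `CC(C)S(=O)(=O)N1CCc2nc(C#Cc3ccccc3)sc2C1`: in this assay compound 2 gives 11 nM.
Compound 3, `O=S(=O)(C1CC1)N1CCc2nc(C#Cc3ccccc3)sc2C1`: in this assay compound 3 gives 34 nM.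

Among the two numbers in hand, compound 3 holds the higher one; its nearest neighbour is compound 2, with a 3.1-fold higher number from compound 2 to compound 3 (0.49 log units; beyond the scatter). Compound 1 sits at the limit of > 10000 nM in this assay, at which 1 of the 3 values shown sits, so its value is a limit and gives no number to compare.

Compound 4, `O=S(=O)(C1CCCCC1)N1CCc2nc(C#Cc3ccccc3)sc2C1`, differs from compound 3 in one place: cyclohexyl in place of cyclopropyl on a sulfonyl sulfur. Going by the values given here, two measured steps bear on this position. The replacement of the (2-methyl-1,3-thiazol-4-yl)carbonyl by a sulfonyl group brought an at least 290-fold lower number from compound 1 to compound 3 (2.46 log units; beyond the scatter), a large step; the swap of isopropyl for cyclopropyl on the sulfonyl sulfur brought a 3.1-fold higher number from compound 2 to compound 3 (0.49 log units; beyond the scatter), a modest one. Compound 4 keeps the sulfonyl, so the large step is already spent, and only the modest kind of shift seen between compound 2 and compound 3 is a guide. A cyclohexyl has not been tried here, so the direction is uncertain.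

Compound 4 is therefore expected to give 50 nM in this assay, within a range from 12 nM to 200 nM; this estimate implies a 1.5-fold higher number from compound 3 to compound 4 (0.17 log units; within the scatter).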

Compound 4, half-maximal inhibitory concentration: 480 nM
For compound 4 the middle estimate is 9.6-fold (0.98 log units) below the measured one, outside the stated range (above it).
By their numbers in this assay, from the lowest: compound 2; then compound 3; then compound 4. At a limit, above all of these: compound 1.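

Going by these compounds alone, the sulfonyl sulfur turns out to be far more sensitive to its substituent than the earlier compounds showed. In this assay, within the data shown here, cyclohexyl in place of cyclopropyl gave a 14-fold higher number from compound 3 to compound 4 (1.15 log units; beyond the scatter), and cyclohexyl in place of isopropyl gave a 44-fold higher number from compound 2 to compound 4 (1.64 log units; beyond the scatter), both large steps, whereas the only earlier change among groups on this sulfur, cyclopropyl in place of isopropyl, gave just a 3.1-fold higher number from compound 2 to compound 3 (0.49 log units; beyond the scatter). Among these three sulfonamides, the cyclohexyl, with the most heavy atoms, carries the highest number, but nothing given here accounts for the size of this loss.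

Going by these compounds, with only isopropyl, cyclopropyl and cyclohexyl on the sulfur, it remains open whether the number climbs gradually with ring size, so that cyclobutyl and cyclopentyl would fall on a smooth path to cyclohexyl, or jumps sharply at some point along the way. On these data alone, it is equally open how this position would respond to a smaller group such as methyl, to a longer open chain such as n-butyl, or to a flat aromatic ring such as phenyl.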